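Swapping the Aryl Group on the Sulfonyl Sulfur

The source may report more compounds than this note shows. Statements on the series, on what has been measured and on what is new or still open speak of the compounds shown alone.

Compound 3 `Cc1ccc(S(=O)(=O)c2cnc3cc(Cl)ccc3c2N2CCC(C)CC2)cc1Cl` was tested in an assay on isolated protein for displacement of a labelled ligand from metabotropic glutamate receptor 5 (Homo sapiens), with a stated time of 60 min, tested at 1 uM (on this read-out lower numbers stand for less inhibition and higher numbers for more inhibition at the one concentration tested (going by the name of the read-out)), where compound 3 gives 89%. This is the lowest of the three numbers, yet the step from compound 1 `Cc1ccc(S(=O)(=O)c2cnc3cc(Cl)ccc3c2N2CCC(C)CC2)cc1`, which gives 94%, is a number 5 percentage points lower from compound 1 to compound 3 (within the scatter), and the step from compound 2 `CC1CCN(c2c(S(=O)(=O)c3ccc(F)c(Cl)c3)cnc3cc(Cl)ccc23)CC1`, which gives 94%, is a number 5 percentage points lower from compound 2 to compound 3 (within the scatter). Compound 4 `COc1cccc(S(=O)(=O)c2cnc3cc(Cl)ccc3c2N2CCC(C)CC2)c1` carries 3-methoxyphenyl in place of 3-chloro-4-methylphenyl on a sulfonyl sulfur. Among the compounds with values here, the closest precedent is the earlier aryl swap on the same sulfonyl sulfur, no change at the digits printed from compound 1 to compound 2 (within the scatter); the smaller edits on that ring, a number 5 percentage points lower from compound 1 to compound 3 (within the scatter) and a number 5 percentage points lower from compound 2 to compound 3 (within the scatter), were likewise within the scatter. A step of a number 1 percentage points lower from compound 3 to compound 4 (within the scatter) is therefore expected, nothing beyond the scatter. Compound 4 is estimated at 88%, between 74% and 97%.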

Compound 4, a percentage reported as inhibition, at one concentration (the size of the read-out at that concentration, not a potency): 93%
The estimate for compound 4 lay 5 percentage points below the measured number, within the range that was stated.
By their numbers in this assay, from the lowest: compounds 3, 4, 1 and 2 (each within the scatter of the next).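

In this assay the steps are a number 4 percentage points higher from compound 3 to compound 4 (within the scatter) and a number 1 percentage points lower from compound 2 to compound 4 (within the scatter) and a number 1 percentage points lower from compound 1 to compound 4 (within the scatter) with 3-methoxyphenyl on the sulfonyl sulfur. Unlike 3-chloro-4-methylphenyl, this group brings a hydrogen-bond acceptor and no chlorine, yet the number stays within the scatter of all three earlier compounds. Nothing available explains why the number holds here.

A single-concentration percentage gives no potency, so any differences in potency among these compounds stay hidden. As far as these compounds go, whether an amine or a carboxylic acid on this aryl ring would shift the number remains open.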